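The compounds below may be only part of what the source reports. "The series", "measured", "known", "first", "only" and "open" are said of these compounds alone.

Compounds measured so far:
- compound 1, `COc1cc2c(cc1OC)CN(C(=O)CN1C(=O)S/C(=C\c3nc4ccccc4n3C(C)C)C1=O)CC2`: 29700 nM
- compound 2, `CC(C)n1c(/C=C2\SC(=O)N(CC(=O)Nc3cc(C(C)(C)C)on3)C2=O)nc2ccccc21`: > 50000 nM
- compound 3, `CCn1c(/C=C2\SC(=O)N(CC(=O)N3CCCCC3)C2=O)nc2ccccc21`: > 50000 nM

Of the compounds shown here, three sharing the same core have been tested in a functional assay on DU-145 cells (Homo sapiens) for inhibition, read by MTT assay, with a stated time of 48 h; on this read-out lower numbers stand for stronger inhibition and higher numbers for weaker inhibition. For the measured compounds named here, compound 1 gives 29700 nM, which is the only actual number among the three. For compound 2 the result is a limit of the assay, > 50000 nM. For compound 3 the result is likewise a limit, > 50000 nM. So compound 1 stands alone as the one compound with a measured value, while the other two sit at the limit of > 50000 nM in this assay, at which 2 of the 3 values shown sit.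

Compound 4, `COc1cc2c(cc1OC)CN(C(=O)CN1C(=O)S/C(=C\c3nc4ccccc4n3C)C1=O)CC2`, has not yet been measured. It differs from compound 1 in one place: methyl in place of isopropyl on an aromatic nitrogen. Going by the values given here, no pair of measured compounds differs in exactly one place, so there is no measured step to set the size of this change against. The expectation for compound 4 is therefore a step of a 1.2-fold higher number from compound 1 to compound 4 (0.07 log units; within the scatter), that is, no shift beyond the usual scatter around the value of compound 1. Compound 4 is thus estimated at 35000 nM, with a range of 12000 nM to 100000 nM.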

Compound 4, half-maximal inhibitory concentration: 37500 nM
Beside the measured number, compound 4's estimate is 1.1-fold (0.03 log units) below it; the range from low to high includes it.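

In this assay, for the compounds shown here, this is the first step in the set that can be read, and it concerns the group on the aromatic nitrogen: methyl in place of isopropyl gives a 1.3-fold higher number from compound 1 to compound 4 (0.10 log units; within the scatter). With the rest of compound 1 kept, going from 1-isopropyl-1H-benzimidazol-2-yl to 1-methyl-1H-benzimidazol-2-yl therefore makes no difference that can be told apart from repeat scatter. Neither compound is far from the point where this read-out stops giving numbers, which leaves little room to see a weakening: the limit of > 50000 nM in this assay, at which 2 of the 4 values shown sit.

Going by these compounds, whether a benzyl group or a longer chain ending in an amine on this nitrogen would move the number remains open. On these data alone, it also remains open whether the same swap would read the same way on a compound with a much lower starting value.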